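This account rests on a few compounds, and the source may have more. Where it says the series, first, only, none or still open, it means among the compounds named here.

In a functional assay on PC-3 cells (Homo sapiens) for antiproliferative activity, read by CCK-8 assay, with a stated time of 6 days (a lower number here means a stronger inhibitor, a higher number a weaker inhibitor), compound 1 `Cc1noc(C)c1-c1cccc(Oc2ccc(C#N)c(C(F)(F)F)c2)c1` is reported as "not determined" (no result reported) and so offers no number to compare. Compound 3 `CCN(c1ccc(C#N)c(Cl)c1)c1cc(-c2cnc3ccccc3c2)ccc1C` gives 3570 nM while compound 2 `N#Cc1ccc(N2CCCc3c(-c4cccnc4)cccc32)cc1C(F)(F)F` gives 7970 nM and thus holds the higher of the two numbers, a weaker result by a gap beyond the usual scatter. Compound 4 `Cn1nccc1-c1cccc2c1CCCN2c1ccc(C#N)c(C(F)(F)F)c1` keeps the core of compound 2 but carries 1-methyl-1H-pyrazol-5-yl in place of pyridin-3-yl on an aromatic carbon. Among the compounds with values here, no measured pair shows what such a swap does, so the only anchor is compound 2 at 7970 nM itself. The estimated change (a 1.1-fold lower number from compound 2 to compound 4 (0.06 log units; within the scatter)) is expected to stay within the scatter, with no firm direction. For compound 4 the expected value is 7000 nM with a likely range of 2500 nM to 20000 nM in repeat measurements.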

Compound 4, half-maximal inhibitory concentration: 9800 nM
Compound 4: the middle estimate sits 1.4-fold (0.15 log units) below what was measured; the range from low to high includes it.
By their numbers in this assay, from the lowest: compound 3; then compounds 2 and 4 (each within the scatter of the next).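

In this assay, placing 1-methyl-1H-pyrazol-5-yl in place of pyridin-3-yl on this aromatic carbon gives a 1.2-fold higher number from compound 2 to compound 4 (0.09 log units; within the scatter), a direct reading at this position. A five-membered aromatic ring with two hetero atoms and a six-membered aromatic ring with one hetero atom therefore cannot be told apart here. Nothing measured here offers an explanation for this result. Still open, on these data alone, is whether a group without an aromatic ring at this carbon, such as an amine or a carboxylic acid, would give a clearly different number.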